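Cyclopropyl for isopropyl on a carbonyl carbon

The compounds below may be only part of what the source reports. "The series", "measured", "known", "first", "only" and "open" are said of these compounds alone.

Of the compounds shown here, three sharing one core have been measured in a functional assay on HepG2 cells (Homo sapiens) for cytotoxicity, read by MTT assay; a lower number here means a stronger inhibitor, a higher number a weaker inhibitor. Compound 1 `COc1ccc(/C=C/C(=O)c2ccc(OC)c3c2OC(C)(C)C=C3)cc1OCCO`, with 2-hydroxyethyl on an oxygen on an aromatic ring, reads > 10000 nM, which is a limit of the assay. With butylcarbonyl on that oxygen, compound 2 `CCCCC(=O)Oc1cc(/C=C/C(=O)c2ccc(OC)c3c2OC(C)(C)C=C3)ccc1OC` gives 100 nM. With isopropylcarbonyl there, compound 3 `COc1ccc(/C=C/C(=O)c2ccc(OC)c3c2OC(C)(C)C=C3)cc1OC(=O)C(C)C` gives 250 nM, the higher of the two actual numbers, and compound 2 is its nearest neighbour.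

Compound 4 `COc1ccc(/C=C/C(=O)c2ccc(OC)c3c2OC(C)(C)C=C3)cc1OC(=O)C1CC1` has cyclopropyl in place of isopropyl on a carbonyl carbon. Two measured steps replace 2-hydroxyethyl rather than the group on the carbonyl carbon: an at least 100-fold lower number from compound 1 to compound 2 (2.00 log units; beyond the scatter) and an at least 40-fold lower number from compound 1 to compound 3 (1.60 log units; beyond the scatter). Both are large, but they start from a limit and say little about this smaller change. The closest guide is a 2.5-fold higher number from compound 2 to compound 3 (0.40 log units; beyond the scatter), a modest step that changes the group at the same place. Compound 4 keeps the same number of heavy atoms as compound 3 in this group, so only a small shift is expected, within the scatter. The expected step is a 1.3-fold lower number from compound 3 to compound 4 (0.10 log units; within the scatter). The estimated value for compound 4 is 200 nM, with an expected range of 80 nM to 500 nM.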

Compound 4, half-maximal inhibitory concentration: 220 nM
Compound 4: middle estimate off by 1.1-fold (0.04 log units), on the low side; the measured number falls inside the stated range.
By their numbers in this assay, from the lowest: compound 2; then compounds 4 and 3 (each within the scatter of the next). At a limit, above all of these: compound 1.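

In this assay, the ring adds nothing measurable at this place: with cyclopropyl in place of isopropyl on a carbonyl carbon, the two numbers stay within the scatter of each other (a 1.1-fold lower number from compound 3 to compound 4 (0.06 log units; within the scatter)). Compound 2 now stands apart from both carbon groups of this size, and butyl holds the same kind of modest gap to cyclopropyl (a 2.2-fold higher number from compound 2 to compound 4 (0.34 log units; beyond the scatter)) that it already held to isopropyl, so the gap does not depend on whether those three carbons form a ring. Compound 1 sits at a limit, so the replacement of 2-hydroxyethyl by cyclopropylcarbonyl can be read only as a bound (an at least 45-fold lower number from compound 1 to compound 4 (1.65 log units; beyond the scatter)), which is now the third carbonyl group to show such a large step: the limit of > 10000 nM in this assay, at which 1 of the 4 values shown sits.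

The compounds shown leave open where a chain longer than butyl, such as hexyl, or a larger ring, such as cyclohexyl, would read on the same carbonyl carbon. They also leave open whether an amine carried on that group would keep the number near those of compound 3 and compound 4 or move it towards that of compound 2.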